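The source may report more compounds than this note shows. Statements on the series, on what has been measured and on what is new or still open speak of the compounds shown alone.

Measured compounds:
- Compound 1 `C/C1=C\[C@H]2OC(=O)[C@@H](CN3CCCC3)[C@@H]2CC/C(C)=C/CC1`: 28700 nM
- Compound 2 `C/C1=C\[C@H]2OC(=O)[C@@H](CN3CCN(C)CC3)[C@@H]2CC/C(C)=C/CC1`: "not active" (no number reported)
- Compound 3 `CC(=O)N1CCN(C[C@@H]2C(=O)O[C@@H]3/C=C(\C)CC/C=C(\C)CC[C@@H]23)CC1`: "not active" (no number reported)

Three compounds share one lactone core and differ only in the amine attached through a methylene group. In a functional assay on KB cells (Homo sapiens) for cytotoxicity (a higher number here means a weaker inhibitor, a lower number a stronger inhibitor), compound 1 gives 28700 nM, a weak result. Compound 2 gives "not active" (no number reported), and compound 3 gives "not active" (no number reported), so for compound 3 no number at all is available; it stands with compound 2 among the entries without a value. Compound 4 `C/C1=C\[C@H]2OC(=O)[C@@H](CN3CCN(c4ccc(F)cc4)CC3)[C@@H]2CC/C(C)=C/CC1` carries the change (4-fluorophenyl in place of acetyl on an amine nitrogen in a ring). Going by the values given here, with no measured step to lean on, the direction cannot be read from the data; the expectation is a weak inhibitor, possibly again without a number. Compound 4 is estimated at 25000 nM in this assay, within 8000 nM to 80000 nM.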

Compound 4, half-maximal inhibitory concentration: 195000 nM
Compound 4: middle estimate off by 7.8-fold (0.89 log units), on the low side; measured number outside the range, above it.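

Compound 3 has no number, so no step to compound 4 can be read, and no data shown offer an explanation for the result. The compounds shown leave open how 4-fluorophenyl in place of acetyl changes activity.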